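Removing the aryl trifluoromethyl in an alpha4/beta2 ligand series

The source may report more compounds than this note shows. Statements on the series, on what has been measured and on what is new or still open speak of the compounds shown alone.

Measured compounds:
- compound 1, `COc1ccc(Nc2cncc(N3CC4CC(C3)N4)c2)cc1`: 0.0598 nM
- compound 2, `Cc1ccc(Nc2cncc(N3CC4CC(C3)N4)c2)cc1`: 0.148 nM
- compound 3, `FC(F)(F)c1ccc(Nc2cncc(N3CC4CC(C3)N4)c2)cc1`: 0.373 nM

In an assay on cell membranes for displacement of a labelled ligand from Neuronal acetylcholine receptor; alpha4/beta2 (Rattus norvegicus) (a higher number here means a weaker inhibitor, a lower number a stronger inhibitor), compound 3 gives the highest of the three numbers. The nearest is compound 2, reached by a 2.5-fold higher number from compound 2 to compound 3 (0.40 log units; beyond the scatter); the furthest is compound 1, reached by a 6.2-fold higher number from compound 1 to compound 3 (0.80 log units; beyond the scatter). Both steps are modest, and both show that exchanging the substituent on this aromatic carbon shifts the number while the shared core is kept the same.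

Compound 4, `c1ccc(Nc2cncc(N3CC4CC(C3)N4)c2)cc1`, has not been measured. It differs from compound 3 by hydrogen in place of trifluoromethyl on an aromatic carbon. Among the measured compounds shown here, no measured pair replaces a substituent with hydrogen at this carbon, so the closest guide is the small spread seen across compounds 1, 2 and 3, in which every substituent change moved this assay by a modest amount. Compound 4 is therefore expected to stay within that spread, most likely with a somewhat lower number than compound 3, an expected step of a 2.5-fold lower number from compound 3 to compound 4 (0.40 log units; beyond the scatter). The estimate for compound 4 in this assay is 0.15 nM, with a range from 0.05 nM to 0.5 nM.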

Compound 4, inhibition constant: 0.0807 nM
Compound 4: middle estimate off by 1.9-fold (0.27 log units), on the high side; measured number inside the range.
By their numbers in this assay, from the lowest: compounds 1, 4 and 2 (each within the scatter of the next, the first and the last beyond it); then compound 3.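

In this assay, compound 4 shows that a substituent on this aromatic carbon is not required for a low number, something compounds 1, 2 and 3 could not show because each of them carries one. Hydrogen in place of trifluoromethyl gives a 4.6-fold lower number from compound 3 to compound 4 (0.66 log units; beyond the scatter) and places compound 4 among the two other compounds. Hydrogen in place of methyl or methoxy gives a 1.8-fold lower number from compound 2 to compound 4 (0.26 log units; within the scatter) and a 1.3-fold higher number from compound 1 to compound 4 (0.13 log units; within the scatter) and so stays within the scatter, leaving trifluoromethyl as the only one of the three groups set apart from hydrogen here.

The compounds shown leave open how an amine, a carboxylic acid or a longer chain such as ethoxy on this carbon would read. Nothing available here explains why trifluoromethyl stands apart.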